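Oxime to Ketone Swap on a Triazole Thioether Series

A few compounds are considered here, and "the series" means these few. Any claim that something is new, unique, unknown or untested is made for them only; others in the source may bear on it.

Compound 1 `O/N=C(/CSc1nnc(-c2ccccc2)n1-c1ccccc1)c1ccccc1` and compound 2 `O=C(CSc1nnc(-c2ccccc2)n1-c1ccccc1)c1ccccc1` share one core and differ in a single place. In a functional assay on the whole organism (strain albino) for inhibition, with Rattus norvegicus as the target, read by paw edema, with a stated time of 3 h, at a dose of 0.28 mmol/kg by the oral route (on this read-out higher numbers stand for more inhibition at the one dose given (going by the name of the read-out) and lower numbers for less inhibition), compound 1 gives 65%, and compound 2 gives 64%. The structural change between them is a group of 8 heavy atoms (7 carbon, 1 oxygen; one six-membered aromatic ring of carbon only) in place of a group of 9 heavy atoms (7 carbon, 1 nitrogen, 1 oxygen; one six-membered aromatic ring of carbon only), on a saturated chain carbon bound to a sulfur, and the resulting step, a number 1 percentage points lower from compound 1 to compound 2 (within the scatter), lies within the scatter of repeated measurements. Compound 3 `C=CCn1c(SC/C(=N/O)c2ccccc2)nnc1-c1cc(OC)c(OC)c(OC)c1` is built on a different core; how its core differs from that of compound 1 is not broken down here. In this assay compound 3 gives 70%, a number within the scatter of both compound 1 and compound 2. Compound 4 `C=CCn1c(SCC(=O)c2ccccc2)nnc1-c1cc(OC)c(OC)c(OC)c1` has not yet been measured. It differs from compound 3 by a group of 8 heavy atoms (7 carbon, 1 oxygen; one six-membered aromatic ring of carbon only) in place of a group of 9 heavy atoms (7 carbon, 1 nitrogen, 1 oxygen; one six-membered aromatic ring of carbon only), on a saturated chain carbon bound to a sulfur, the same change, at the same place, as that between compound 1 and compound 2. Since that change earlier moved the read-out by only a number 1 percentage points lower from compound 1 to compound 2 (within the scatter), a step of similar size is expected here, namely a number 1 percentage points lower from compound 3 to compound 4 (within the scatter). Compound 4 is therefore estimated at 69%, most likely falling between 60% and 78%.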

Compound 4, a percentage reported as inhibition, in the whole organism at one dose (the size of the read-out at that dose, not a potency): 66%
Estimate against measurement, compound 4: 3 percentage points above, within the range that was stated.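

In this assay, putting benzoyl in place of the oxime-bearing group on a saturated chain carbon bound to a sulfur gives a number 4 percentage points lower from compound 3 to compound 4 (within the scatter) on the second core. Set beside the first case, this step does not differ from it: the same change on two cores in this assay, a number 1 percentage points lower (within the scatter) from compound 1 to compound 2 and a number 4 percentage points lower (within the scatter) from compound 3 to compound 4, 3 percentage points apart, within the scatter of two such steps. This shows that, on these two cores, the swap carries over without a step beyond the usual scatter, but two cores, one dose and one time point are thin support for a general rule, and the result does not show that the two groups would remain interchangeable on another core or under other conditions.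

The compounds shown leave open whether a different group at this place, such as an amine, a carboxylic acid or a longer chain, would shift the inhibition of paw swelling by more than the scatter. They also leave open how each part of the difference between the two cores bears on the read-out.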